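The source may report more compounds than this note shows. Statements on the series, on what has been measured and on what is new or still open speak of the compounds shown alone.

Measured so far:
compound 1, `Nc1nc(-c2ccc(Cl)cc2)c(CC(=O)O)s1` – > 100000 nM
compound 2, `O=C(O)Cc1sc(C(c2ccc(F)cc2)c2ccc(F)cc2)nc1-c1ccnc(N2CCC2)c1` – 660 nM

Both were tested in an in vitro assay on HEK385-7 cells for displacement of a labelled ligand from prostaglandin D2 receptor 2 (Homo sapiens); a higher number here means a weaker inhibitor, a lower number a stronger inhibitor. For compound 1 the result is not a number but a limit of the assay, (the limit of > 100000 nM in this assay, at which 1 of the 2 values shown sits). Going by the values given here, compound 2 therefore stands alone as the only real number in this assay, with 660 nM, and no step between two measured numbers exists to guide the next move.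

Compound 3, `NS(=O)(=O)c1cccc(-c2nc(C(c3ccc(F)cc3)c3ccc(F)cc3)sc2CC(=O)O)c1`, keeps the shared core of compound 2 and changes one group: 3-sulfamoylphenyl in place of 2-(azetidin-1-yl)pyridin-4-yl on an aromatic carbon. A change of this size, swapping one aryl group for another of the same atom count, could shift the read-out either way. With nothing measured to anchor it, the expected step is a modest loss, a 2.3-fold higher number from compound 2 to compound 3 (0.36 log units; beyond the scatter), and compound 3 is estimated at 1500 nM, somewhere between 400 nM and 6000 nM.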

Compound 3, half-maximal inhibitory concentration: 140 nM
Estimate against measurement, compound 3: 11-fold (1.03 log units) above, and the stated range ends above it.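

Putting 3-sulfamoylphenyl in place of 2-(azetidin-1-yl)pyridin-4-yl on the aromatic carbon next to the ring nitrogen gives a 4.7-fold lower number from compound 2 to compound 3 (0.67 log units; beyond the scatter) in this assay. Going by these compounds alone, this is the first step between two real numbers here, and it shows that this position responds to the aryl group it carries and accepts a group with a hydrogen-bond donor, which the group that leaves does not have. The two groups differ in several ways at once, and nothing measured here explains the gain.

As far as these compounds go, it remains open whether the gain comes from the sulfamoyl group itself or from the ring that carries it. An unsubstituted phenyl at this position, or a methylsulfonyl group in place of the sulfamoyl group, would help to separate these two possibilities.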